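Next aryl swap after two flat readings

This account rests on a few compounds, and the source may have more. Where it says the series, first, only, none or still open, it means among the compounds named here.

- compound 1 `Cc1oc2c([C@H]3CCN(C)C[C@H]3O)c(O)cc(O)c2c(=O)c1C(O)c1csc([N+](=O)[O-])c1` gives 0% 
- compound 2 `COc1ccc(C(O)c2c(C)oc3c([C@H]4CCN(C)C[C@H]4O)c(O)cc(O)c3c2=O)cc1Br` gives 0% 

In a functional assay on PC-3 cells (Homo sapiens) for inhibition, read by MTT assay, with a stated time of 48 h, tested at 10 uM (on this read-out higher numbers stand for more inhibition of growth at the one concentration tested and lower numbers for less inhibition of growth), compound 2 stands level with compound 1 on the numbers shown. Compound 3 `Cc1oc2c([C@H]3CCN(C)C[C@H]3O)c(O)cc(O)c2c(=O)c1C(O)c1cc(F)cc(F)c1` follows from compound 2 through 3,5-difluorophenyl in place of 3-bromo-4-methoxyphenyl on a saturated chain carbon bound to an aromatic carbon and an oxygen on a saturated carbon with 3,5-difluorophenyl in place of 3-bromo-4-methoxyphenyl. Within the data shown here, only one measured step bears on this, namely no change at the digits printed from compound 1 to compound 2 (within the scatter) at the same place. That single step gives no sign of direction, so no move beyond the scatter is expected in this assay for this change. The estimated step is a number 3 percentage points higher from compound 2 to compound 3 (within the scatter) and stays within the scatter. For compound 3 the estimate is 3% with an expected range of 0% to 15% at this stage.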

Compound 3, percent growth inhibition at one concentration: 0%
Estimate against measurement, compound 3: 3 percentage points above; the range from low to high includes it.
By their numbers in this assay, from the lowest: compounds 1, 2 and 3 (each within the scatter of the next).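

At the saturated chain carbon bound to an aromatic carbon and an oxygen on a saturated carbon, 3,5-difluorophenyl in place of 3-bromo-4-methoxyphenyl gives no change at the digits printed from compound 2 to compound 3 (within the scatter) in this assay, and 3,5-difluorophenyl in place of 5-nitrothiophen-3-yl gives no change at the digits printed from compound 1 to compound 3 (within the scatter). The reading now stays flat for a third aryl group, one with no hydrogen-bond acceptor. No supporting data explain this flat reading. On these data alone, whether a carboxylic acid or an aminomethyl group at this place would alter the reading stays open. With all three compounds level, the contribution of the shared core also remains unresolved.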